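The source may report more compounds than this note shows. Statements on the series, on what has been measured and on what is new or still open speak of the compounds shown alone.

Measured in a functional assay on A549 cells (Homo sapiens) for cytotoxicity, read by MTT assay, with a stated time of 72 h; a higher number here means a weaker inhibitor, a lower number a stronger inhibitor:

Compound 1 `CN(C)CCn1cnnc1-c1cc(Oc2ccc(NC(=O)N/N=C/c3cccc(Cl)c3Cl)cc2F)ccn1`: 1090 nM
Compound 2 `CN(C)CCn1cnnc1-c1cc(Oc2ccc(NC(=O)N/N=C/c3cc(Br)c(O)c(Br)c3)cc2F)ccn1`: > 100000 nM, a limit of the assay rather than a number
Compound 3 `CN(C)CCn1cnnc1-c1cc(Oc2ccc(NC(=O)N/N=C/c3c[nH]c4ccccc34)cc2F)ccn1`: 820 nM

Compound 1 has the higher of the two numbers, but the gap a 1.3-fold lower number from compound 1 to compound 3 (0.12 log units; within the scatter) lies within the scatter. Compound 4 `CN(C)CCn1cnnc1-c1cc(Oc2ccc(NC(=O)N/N=C/c3ccccc3)cc2F)ccn1` differs from compound 1 by phenyl in place of 2,3-dichlorophenyl on a carbon with a double bond to nitrogen. For the measured compounds named here, no measured step removes the two chlorines alone; the closest guides are a 1.3-fold lower number from compound 1 to compound 3 (0.12 log units; within the scatter), a small change, and an at least 91-fold higher number from compound 1 to compound 2 (1.96 log units; beyond the scatter), a large loss with a hydroxy group added. A bare phenyl sits between these cases, so for compound 4 a step of a 1.7-fold higher number from compound 1 to compound 4 (0.22 log units; within the scatter) in this assay is expected, not clearly beyond the scatter. Compound 4 is estimated at 1800 nM, between 600 nM and 6000 nM.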

Compound 4, half-maximal inhibitory concentration: 1860 nM
Compound 4: middle estimate off by 1.0-fold (0.01 log units), on the low side, and the stated range covers the measured number.
By their numbers in this assay, from the lowest: compounds 3, 1 and 4 (each within the scatter of the next, the first and the last beyond it). At a limit, above all of these: compound 2.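

In this assay, the two chlorines can go with no change beyond the scatter: a 1.7-fold higher number from compound 1 to compound 4 (0.23 log units; within the scatter). Phenyl in place of 1H-indol-3-yl is a modest step, a 2.3-fold higher number from compound 3 to compound 4 (0.36 log units; beyond the scatter), although 2,3-dichlorophenyl stays within the scatter of both. The 3,5-dibromo-4-hydroxyphenyl value is a limit, not a number, so an at least 53-fold lower number from compound 2 to compound 4 (1.73 log units; beyond the scatter) is only a bound, and the bare phenyl does not share that loss: the limit of > 100000 nM in this assay, at which 1 of the 4 values shown sits.

Whether the loss follows the hydroxy group or the two bromines stays open, since 4-hydroxyphenyl and 3,5-dibromophenyl are not among the compounds shown. From the compounds shown here alone, how an amine or a carboxylic acid on the phenyl would read also stays open.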